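Side-chain step from compound 3 to compound 4

The source may report more compounds than this note shows. Statements on the series, on what has been measured and on what is new or still open speak of the compounds shown alone.

- compound 1 `COc1cc(-c2nc3ccccc3s2)ccc1OCC(=O)NNC(O)CN(C)CC(=O)O`: 3030 nM
- compound 2 `COc1cc(-c2nc3ccccc3s2)ccc1OCC(=O)NNC(=O)CNC(=N)NCCC[C@H](N[N+](=O)[O-])C(=O)O`: 3490 nM
- compound 3 `CCOC(=O)CN(C)CC(=O)NNC(=O)COc1ccc(-c2nc3ccccc3s2)cc1OC`: 3180 nM

In a functional assay on HepG2 cells (Homo sapiens) for inhibition, read by MTT assay, with a stated time of 3 days (a higher number here means a weaker inhibitor, a lower number a stronger inhibitor), compound 3 gives 3180 nM, and its value lies within the scatter of those of both compound 1 and compound 2. The three measured values therefore form a single group, with no order to be read among them.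

The next compound is compound 4 `CCOC(=O)[C@@H]1CCCN1CC(=O)NNC(=O)COc1ccc(-c2nc3ccccc3s2)cc1OC`. It carries 2-(ethoxycarbonyl)pyrrolidin-1-yl in place of ((ethoxycarbonyl)methyl)(methyl)amino on a saturated chain carbon bound to a carbonyl carbon.

Within the data shown here, one measured step bears on this change: a 1.0-fold higher number from compound 1 to compound 3 (0.02 log units; within the scatter). It alters the same side of the molecule, and its size lies within the scatter. Compound 2, at 3490 nM, has a different side chain again, and its value sits in the same range. Among the measured compounds shown here, no measured compound carries a five-membered non-aromatic ring in this side chain, so the data do not test that feature directly, and the expected range is kept wide.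

In this assay the expected size is a 1.0-fold higher number from compound 3 to compound 4 (0.00 log units; within the scatter), which means no expected shift beyond the scatter. The estimated value for compound 4 is 3200 nM. The expected range for compound 4 runs from 1500 nM to 6800 nM.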

Compound 4, half-maximal inhibitory concentration: 2800 nM
Compound 4: the middle estimate sits 1.1-fold (0.06 log units) above what was measured; measured number inside the range.
By their numbers in this assay, from the lowest: compounds 4, 1, 3 and 2 (each within the scatter of the next).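

In this assay, 2-(ethoxycarbonyl)pyrrolidin-1-yl in place of ((ethoxycarbonyl)methyl)(methyl)amino on a saturated chain carbon bound to a carbonyl carbon gives a 1.1-fold lower number from compound 3 to compound 4 (0.06 log units; within the scatter). Among these compounds, this is the first direct reading of a five-membered non-aromatic ring in this side chain: the ring, the defined stereocentre and the move from 8 to 10 heavy atoms come together in this step, yet the step stays within the scatter, so no order can be read between the two compounds. No measured evidence accounts for this result.

Both compounds in this step keep the ethyl ester, so the compounds shown leave open whether the same pyrrolidine ring bearing a free carboxylic acid, or a pyrrolidine ring with no ester at all, would read the same. Also open, on these data alone, are the other configuration at the stereocentre and a six-membered piperidine ring carrying the same ester, and because the ring, the stereocentre and the added heavy atoms change as one, their separate contributions cannot be told apart.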